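The compounds below may be only part of what the source reports. "The series", "measured", "known", "first", "only" and "open" are said of these compounds alone.

Going by the values given here, compound 2 `c1csc(-c2noc(-c3ccc(C4=NCCN4)cc3)n2)c1` gives the lowest of the two numbers so far in an assay for inhibition of Amine oxidase [flavin-containing] B (Homo sapiens), read by fluorescence and spectrophotometry, using microsomes, with stated times of 30 min and 20 min (a higher number here means a weaker inhibitor, a lower number a stronger inhibitor), at 890 nM; the only neighbour, compound 1 `c1ccc(OCc2noc(-c3ccc(C4=NCCN4)cc3)n2)cc1`, gives 9980 nM. Among the compounds with values here, the single measured step, an 11-fold lower number from compound 1 to compound 2 (1.05 log units; beyond the scatter), shows that a ring attached directly to the shared core outperforms a phenoxymethyl arm. Compound 3 `Clc1cccc(-c2noc(-c3ccc(C4=NCCN4)cc3)n2)c1` carries 3-chlorophenyl in place of thiophen-2-yl on an aromatic carbon. That step bears on it only loosely, since here one directly attached ring replaces another. No change beyond the scatter is expected, a 1.1-fold lower number from compound 2 to compound 3 (0.05 log units; within the scatter), because compound 2 already sits at 890 nM with a ring in the same place. Compound 3 is therefore estimated at 800 nM, within 250 nM to 2800 nM.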

Compound 3, half-maximal inhibitory concentration: 64 nM
Estimate against measurement, compound 3: 13-fold (1.10 log units) above; measured number below the stated range.
By their numbers in this assay, from the lowest: compound 3; then compound 2; then compound 1.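

On the aromatic carbon between two ring nitrogen atoms, the identity of the directly attached ring matters in this assay: 3-chlorophenyl in place of thiophen-2-yl gives a 14-fold lower number from compound 2 to compound 3 (1.14 log units; beyond the scatter) at this place. Going by these compounds alone, replacing the phenoxymethyl arm with 3-chlorophenyl gives a 160-fold lower number from compound 1 to compound 3 (2.19 log units; beyond the scatter), the widest step so far. No evidence here explains the gain from 3-chlorophenyl. The compounds shown do not separate the contribution of the chlorine from that of the six-membered ring. Unsubstituted phenyl, 4-chlorophenyl and 3-methoxyphenyl remain open at this place.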